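Trifluoromethyl Added to a Weak Antiproliferative Series

The source may report more compounds than this note shows. Statements on the series, on what has been measured and on what is new or still open speak of the compounds shown alone.

Compound 1 `CC(O)(CSc1cccc(C(F)(F)F)c1)C(=O)Nc1cccc(S(F)(F)(F)(F)F)c1`: 20200 nM
Compound 2 `CC(O)(CSc1cc(C(F)(F)F)cc(C(F)(F)F)c1)C(=O)Nc1cccc(S(F)(F)(F)(F)F)c1`: 4000 nM
Compound 3 `CC(O)(COc1ccc(C#N)cc1)C(=O)Nc1ccc(S(F)(F)(F)(F)F)cc1`: 100000 nM

In a functional assay on VCaP cells (Homo sapiens) for antiproliferative activity, read by propidium iodide staining, with a stated time of 96 h (a higher number here means a weaker inhibitor, a lower number a stronger inhibitor), compound 3 gives the highest of the three numbers. The difference between the core of compound 3 and the core of compound 1 is not broken down here. Compound 4 `CC(O)(COc1ccc(C#N)cc1C(F)(F)F)C(=O)Nc1ccc(S(F)(F)(F)(F)F)cc1` is not yet measured; it carries trifluoromethyl in place of hydrogen on an aromatic carbon. The same kind of change, (trifluoromethyl in place of hydrogen on an aromatic carbon), gave a 5.1-fold lower number from compound 1 to compound 2 (0.70 log units; beyond the scatter). The two places are not the same: in compound 2 the group sits meta to a large group and meta to a trifluoromethyl group, whereas in compound 4 it sits ortho to a large group and meta to a cyano group. Resting on that earlier step alone, compound 4 is expected to show a 2.9-fold lower number from compound 3 to compound 4 (0.46 log units; beyond the scatter), a value estimated near 35000 nM in this assay, between 12000 nM and 100000 nM.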

Compound 4, half-maximal inhibitory concentration: 100000 nM
Estimate against measurement, compound 4: 2.9-fold (0.46 log units) below, and the stated range covers the measured number.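

Trifluoromethyl in place of hydrogen on an aromatic carbon gave no change at the digits printed from compound 3 to compound 4 (within the scatter) in this assay, so the earlier gain did not carry over to this core, and the two steps differ: the same change on two cores in this assay, a 5.1-fold lower number (0.70 log units; beyond the scatter) from compound 1 to compound 2 and no change at the digits printed (within the scatter) from compound 3 to compound 4, 5.1-fold (0.70 log units) apart, beyond the scatter of two such steps A gain on the core of compound 1 therefore cannot be assumed on the core of compound 3. This does not show what separates the two steps: the cores differ, the group's surroundings differ, and each core offers a single pair.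

The compounds shown leave open whether an amine or a carboxylic acid in place of that trifluoromethyl would change the number for compound 4. They also leave open whether trifluoromethyl elsewhere on that ring would do so.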